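The compounds below may be only part of what the source reports. "The series", "measured", "known", "first", "only" and "open" are said of these compounds alone.

Compound 1, `N#Cc1c(-c2ccccc2)c(C#N)c(=O)n(/N=C/c2cn(-c3ccccc3)nc2-c2ccccc2)c1N`: 180 ug/mL
Compound 2, `N#Cc1c(-c2ccccc2O)c(C#N)c(=O)n(/N=C/c2cn(-c3ccccc3)nc2-c2ccccc2)c1N`: 162 ug/mL
Compound 3, `Cc1ccc(-c2c(C#N)c(N)n(/N=C/c3cn(-c4ccccc4)nc3-c3ccccc3)c(=O)c2C#N)cc1`: 98 ug/mL

All three compounds share one core and differ only in the aryl group attached to it. They were tested in an ADME assay on NIH3T3 cells (Mus musculus) for cytotoxicity, read by MTT assay; on this read-out lower numbers stand for stronger inhibition and higher numbers for weaker inhibition. Compound 1 gives 180 ug/mL, compound 2 gives 162 ug/mL, and compound 3 gives 98 ug/mL. The step from compound 1 to compound 2 is a 1.1-fold lower number from compound 1 to compound 2 (0.05 log units; within the scatter), the step from compound 1 to compound 3 is a 1.8-fold lower number from compound 1 to compound 3 (0.26 log units; within the scatter), and the step from compound 2 to compound 3 is a 1.7-fold lower number from compound 2 to compound 3 (0.22 log units; within the scatter). Each of these steps lies within the scatter, so the three compounds cannot be told apart on these numbers, and compound 3 stands together with the other two.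

Compound 4, `COc1cc(-c2c(C#N)c(N)n(/N=C/c3cn(-c4ccccc4)nc3-c3ccccc3)c(=O)c2C#N)cc(OC)c1OC`, has not yet been measured. It differs from compound 3 in one place: 3,4,5-trimethoxyphenyl in place of 4-methylphenyl on an aromatic carbon. For the measured compounds named here, the steps that bear on this change are those that alter the same aryl group, the step from compound 1 to compound 3 and the step from compound 2 to compound 3, and both stayed within the scatter. On that basis no step beyond the scatter is expected in this assay. Compound 4 is therefore expected to give about 110 ug/mL in this assay, with a likely range from 50 ug/mL to 240 ug/mL. This estimate corresponds to an expected step of a 1.1-fold higher number from compound 3 to compound 4 (0.05 log units; within the scatter).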

Compound 4, half-maximal inhibitory concentration: 64 ug/mL
For compound 4 the middle estimate is 1.7-fold (0.24 log units) above the measured one, and the stated range covers the measured number.
By their numbers in this assay, from the lowest: compounds 4, 3, 2 and 1 (each within the scatter of the next, the first and the last beyond it).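

In this assay, the aryl position on the shared core now gives its first steps beyond the scatter, with a 2.8-fold lower number from compound 1 to compound 4 (0.45 log units; beyond the scatter) and a 2.5-fold lower number from compound 2 to compound 4 (0.40 log units; beyond the scatter) as the 3,4,5-trimethoxyphenyl group enters. The change from 4-methylphenyl stays within the scatter at a 1.5-fold lower number from compound 3 to compound 4 (0.19 log units; within the scatter) and leaves these two compounds standing together, even though the entering group has more heavy atoms and brings hydrogen-bond acceptors that the leaving group lacks. Nothing in the information at hand gives a cause for these steps.

The compounds shown cannot tell whether the separation from the phenyl and 2-hydroxyphenyl compounds needs all the methoxy groups together, and a phenyl ring carrying a single methoxy group would help to settle that. Also open, as far as these compounds go, is how the same position would read with an amine or a carboxylic acid on the phenyl ring, or with a non-aromatic group such as cyclohexyl in place of the ring.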